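Cyclopropyl to Methyl in a Narrow Range of Values

A few compounds are considered here, and "the series" means these few. Any claim that something is new, unique, unknown or untested is made for them only; others in the source may bear on it.

In an ADME assay on the whole organism (strain Han-Wistar) for pharmacokinetics, with Rattus norvegicus as the target, read by LC-MS, at a dose of 1 mg/kg by the intravenous route (on this read-out higher numbers stand for wider distribution into tissues and lower numbers for narrower distribution), compound 1 `Cc1ccc([C@@H](C)Oc2cc3onc(CCC(=O)O)c3cc2Cl)nc1` gives 0.31 L/kg, compound 2 `O=C(O)CCn1c(=O)oc2cc(Cl)c(Cl)cc21` gives 0.28 L/kg, and compound 3 `O=C(O)CCn1c(=O)oc2cc(OCC3CC3)c(Cl)cc21` gives 0.26 L/kg. Compound 3 therefore stands level with the other two, since all three values lie within the usual scatter of repeated measurements. The next structure is compound 4 `CCOc1cc2oc(=O)n(CCC(=O)O)c2cc1Cl`, and the change is methyl in place of cyclopropyl on a saturated chain carbon bound to an oxygen on an aromatic ring. Put simply, methyl takes the place of cyclopropyl on a saturated chain carbon bound to an oxygen on an aromatic ring, which turns cyclopropylmethoxy into ethoxy. For the measured compounds named here, only one measured step involves this group: cyclopropylmethoxy in place of chloro on an aromatic carbon. Because of a 1.1-fold lower number from compound 2 to compound 3 (0.03 log units; within the scatter), no step beyond the scatter is expected in this assay, although a single step is thin evidence. The expected change is a 1.0-fold higher number from compound 3 to compound 4 (0.02 log units; within the scatter). Compound 4 is estimated at 0.27 L/kg, with an expected range of 0.18 L/kg to 0.4 L/kg.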

Compound 4, volume of distribution at steady state: 0.36 L/kg
For compound 4 the middle estimate is 1.3-fold (0.12 log units) below the measured one, and the stated range covers the measured number.
By their numbers in this assay, from the lowest: compounds 3, 2, 1 and 4 (each within the scatter of the next).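

In this assay, methyl in place of cyclopropyl gives a 1.4-fold higher number from compound 3 to compound 4 (0.14 log units; within the scatter), so at this place, on a saturated chain carbon bound to an oxygen on an aromatic ring, losing the three-membered ring does not move the number beyond the scatter. Ethoxy in place of chloro on an aromatic carbon gives a 1.3-fold higher number from compound 2 to compound 4 (0.11 log units; within the scatter), which means that chloro, cyclopropylmethoxy and ethoxy now all stand level on that aromatic carbon. No measurement shown here offers a reason for these numbers.

Going by these compounds, whether an amine on this chain, or a longer chain such as butyl in place of the ethyl, would take the number in this assay beyond the scatter stays open. On these data alone, each step also rests on a single pair of compounds, so it remains unknown whether the same change would behave alike on another core.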